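The compounds below may be only part of what the source reports. "The series", "measured", "known", "first", "only" and "open" are said of these compounds alone.

In an ADME assay for permeability, using PAMPA, at pH 7.4 (a higher number here means that the compound crosses the layer faster, a lower number that the compound crosses the layer more slowly), compound 1 `Cc1cc(NC(=O)Nc2ccc(C)c(Cl)c2)c2ccccc2n1` stands second highest of three numbers at 262 10^-6 cm/s in this small set. Compound 3 `Cc1ccc(NC(=O)Nc2cc(C)nc3ccccc23)cc1` sits higher at 669 10^-6 cm/s and compound 2 `Cc1cc(NC(=O)Nc2cccc(C(N)=O)c2)c2ccccc2n1` sits far lower at 2 10^-6 cm/s on the same scale. Compound 4 `COc1ccc(NC(=O)Nc2cc(C)nc3ccccc23)cc1Cl` is still unmeasured and differs from compound 1 by methoxy in place of methyl on an aromatic carbon. That carbon is ortho to a chloro group and para to a large group. Among the measured compounds shown here, no measured step makes this same swap. The closest evidence is a change at that chloro group, hydrogen in place of chloro (a 2.6-fold higher number from compound 1 to compound 3 (0.41 log units; beyond the scatter)), which is modest. For the measured compounds named here, with only this one step to go on, a change no larger than that is expected in this assay for the swap, and the data give no firm direction, so only a slight drop is assumed. The expected step is small (a 1.3-fold lower number from compound 1 to compound 4 (0.12 log units; within the scatter)) and nothing beyond the scatter is anticipated. The estimated value for compound 4 is 200 10^-6 cm/s with an expected range from 80 10^-6 cm/s to 450 10^-6 cm/s on this scale.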

Compound 4, apparent permeability: 336 10^-6 cm/s
For compound 4 the middle estimate is 1.7-fold (0.23 log units) below the measured one; measured number inside the range.
By their numbers in this assay, from the lowest: compound 2; then compounds 1, 4 and 3 (each within the scatter of the next, the first and the last beyond it).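

In this assay the carbon ortho to a chloro group and para to a large group now has a direct reading: methoxy in place of methyl gives a 1.3-fold higher number from compound 1 to compound 4 (0.11 log units; within the scatter) and stays within the scatter. This carbon can therefore take one more heavy atom, an oxygen that adds a hydrogen-bond acceptor, with no change that can be told from repeat-measurement noise, something the earlier step at the chloro group could not show. Nothing measured here speaks to why the number holds.

Going by these compounds, this is one swap, made with the chloro group in place, so it remains open whether the same swap would read alike on compound 3, which lacks that group. On these data alone, how this carbon would respond to an amine, a carboxylic acid or a longer chain such as ethoxy also remains open.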